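A methyl in place of fluoro on the fused ring

The source may hold more compounds than are shown below. What is called first, only, known or untested is meant among the compounds shown, and "the series" means these compounds.

Of the compounds shown here, three have been measured in an assay for inhibition of high affinity nerve growth factor receptor (Homo sapiens), read by HTRF, with a stated time of 30 min, in the presence of a further agent that is not named here; on this read-out higher numbers stand for weaker inhibition and lower numbers for stronger inhibition. Compound 1 `Fc1ccc(CNc2nc(Nc3cc(C4CC4)[nH]n3)c3ccccc3n2)c(F)c1` gives 4.7 nM, compound 2 `Cc1ccc2nc(NCc3ccc(F)cc3F)nc(Nc3cc(C)[nH]n3)c2c1` gives 110 nM, and compound 3 `Cc1cc(Nc2nc(NCc3ccc(F)cc3F)nc3cc(F)ccc23)n[nH]1` gives 62 nM. Compound 3 stands second highest of the three; compound 2 sits within the usual scatter of it, while compound 1 gives a number well below it, beyond the scatter. Compound 4 `Cc1ccc2c(Nc3cc(C)[nH]n3)nc(NCc3ccc(F)cc3F)nc2c1` differs from compound 3 in one place: methyl in place of fluoro on an aromatic carbon. Going by the values given here, no step between measured compounds shows this exchange. Compound 3 and compound 2 both carry a small group on the fused ring and give numbers within scatter of each other, so the change in this assay is expected to be small, with the estimated step of a 1.3-fold higher number from compound 3 to compound 4 (0.11 log units; within the scatter) not beyond the scatter. For compound 4 the expected value is 80 nM, in a range from 35 nM to 180 nM.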

Compound 4, half-maximal inhibitory concentration: 27 nM
Estimate against measurement, compound 4: 3.0-fold (0.47 log units) above, outside the stated range (below it).
By their numbers in this assay, from the lowest: compound 1; then compound 4; then compounds 3 and 2 (each within the scatter of the next).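

In this assay the exchange of fluoro for methyl on this aromatic carbon gives a 2.3-fold lower number from compound 3 to compound 4 (0.36 log units; beyond the scatter), a modest step, yet the first at this place that clears the scatter. So this place on the fused ring responds to the exchange, even though one heavy atom replaces one and neither group carries a hydrogen-bond donor or acceptor. No measurement shown explains the step. On these data alone, whether an amine, a methoxy group or a longer chain at this place would extend the step stays open, as does whether it would hold on the core of compound 1.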